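This account rests on a few compounds, and the source may have more. Where it says the series, first, only, none or still open, it means among the compounds named here.

Measured so far:
Compound 1, `CCOc1c(/C(C)=C\C=C\C(C)=C\C(=O)O)cc(C(C)C)cc1C(C)C`, gives > 10000 nM in an assay on CV-1 cells (Cercopithecidae) with retinoic acid receptor gamma (Homo sapiens) as the target (a lower number here means a stronger inhibitor, a higher number a weaker inhibitor), a limit of the assay.
Compound 2, `C/C(=C\C(=O)O)c1ccc2scc(-c3cc(C(C)C)cc(C(C)C)c3OCCCF)c2c1`, gives > 10000 nM in this assay, a limit of the assay.

Compound 2 therefore stands where compound 1 stands: the limit of > 10000 nM in this assay, at which 2 of the 2 values shown sit. For the measured compounds named here, neither value is a number, so no step between the two measured compounds can be stated, and nothing beyond the shared limit can be read from them. Compound 3, `COc1c(-c2csc3ccc(/C(C)=C/C(=O)O)cc23)cc(C(C)C)cc1C(C)C`, is not yet measured. It differs from compound 2 by hydrogen in place of 2-fluoroethyl on a saturated chain carbon bound to an oxygen on an aromatic ring; cut one bond further out, 3-fluoropropoxy becomes methoxy. Going by the values given here, with compound 2 giving only a limit, no measured step guides the direction, and the account expects compound 3 to stay close to that limit, with any change no larger than the usual scatter, though a number inside the measurable range cannot be ruled out. Compound 3 is expected to give 8000 nM in this assay, between 1000 nM and 40000 nM. This corresponds to an expected step of an at least 1.2-fold lower number from compound 2 to compound 3 (0.09 log units; that floor lies within the scatter).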

Compound 3, inhibition constant: > 10000 nM
Compound 3: only a limit was reported (the forecaster's own chance of this, stated with the estimate: 60%); middle value at least 1.2-fold (0.09 log units) from the limit.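

Compound 3 gives > 10000 nM in this assay, a limit of the assay. No step can therefore be read between compound 2 and compound 3, and all the compounds shown sit at one limit: the limit of > 10000 nM in this assay, at which 3 of the 3 values shown sit.

The compounds shown leave open what number any of them would give in this assay, and whether replacing 3-fluoropropoxy with methoxy changes it.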